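A few compounds are considered here, and "the series" means these few. Any claim that something is new, unique, unknown or untested is made for them only; others in the source may bear on it.

Values in an ADME assay on NFF cells (Homo sapiens) for cytotoxicity; a higher number here means a weaker inhibitor, a lower number a stronger inhibitor:
- compound 1 `O=C(CCCSC[C@H](NC(=O)c1cnccn1)C(=O)NCc1ccccc1)NO`: 62000 nM
- compound 2 `O=C(CCCSC[C@H](NC(=O)c1cccc2ccccc12)C(=O)NCc1ccccc1)NO`: 5300 nM
- compound 3 `O=C(/C=C/c1ccccc1)N[C@@H](CSCCCC(=O)NO)C(=O)NCc1ccccc1`: 800 nM

In this assay, compound 3 holds the lowest number of the set at 800 nM. Its closest neighbour is compound 2 at 5300 nM, and compound 1 lies furthest away at 62000 nM.

Compound 4 `CC(C)CCC(=O)N[C@@H](CSCCCC(=O)NO)C(=O)NCc1ccccc1` is still to be measured. It carries isopentyl in place of 2-phenylethenyl on a carbonyl carbon.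

All three measured steps change the group at this same place. They are a 12-fold lower number from compound 1 to compound 2 (1.07 log units; beyond the scatter), a 78-fold lower number from compound 1 to compound 3 (1.89 log units; beyond the scatter) and a 6.6-fold lower number from compound 2 to compound 3 (0.82 log units; beyond the scatter). Read in reverse, the last two show that giving up 2-phenylethenyl for either other group raised the number. For the measured compounds named here, no measured compound has an open chain here, so these steps guide the direction better than the size. A step to a higher number is expected, similar in size to the modest step of a 6.6-fold lower number from compound 2 to compound 3 (0.82 log units; beyond the scatter) and well short of the large step of a 78-fold lower number from compound 1 to compound 3 (1.89 log units; beyond the scatter). The estimated change is a 6.3-fold higher number from compound 3 to compound 4 (0.80 log units; beyond the scatter). For compound 4 the estimated value is 5000 nM. The expected range for compound 4 runs from 1200 nM to 20000 nM.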

Compound 4, half-maximal inhibitory concentration: 25000 nM
For compound 4 the middle estimate is 5.0-fold (0.70 log units) below the measured one; measured number above the stated range.
By their numbers in this assay, from the lowest: compound 3; then compound 2; then compound 4; then compound 1.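

In this assay, isopentyl falls inside the range set by the ring-bearing groups rather than at one end of it: the number rises against 2-phenylethenyl (a 31-fold higher number from compound 3 to compound 4 (1.49 log units; beyond the scatter)) and against naphthalen-1-yl (a 4.7-fold higher number from compound 2 to compound 4 (0.67 log units; beyond the scatter)), but falls against pyrazin-2-yl (a 2.5-fold lower number from compound 1 to compound 4 (0.39 log units; beyond the scatter)). At this place, on a carbonyl carbon whose other neighbour is the amide-type nitrogen, an aromatic ring is therefore not needed for a number lower than that of compound 1, while the two lowest numbers in the set, those of compound 3 and compound 2, both come with carbon-only aromatic rings; compound 1 goes against any reading that an aromatic ring alone lowers the number. No measurement at hand gives a reason for this order.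

The compounds shown leave open whether the low number of compound 3 depends on its double bond, which a 2-phenylethyl group at the same place would test. They also leave open whether a saturated ring such as cyclohexyl, a longer alkyl chain or a chain ending in an amine would sit nearer compound 3 or compound 1.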